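Working notes on compound 4 and its neighbours

This account rests on a few compounds, and the source may have more. Where it says the series, first, only, none or still open, it means among the compounds named here.

Three compounds of the shared core have numbers in a functional assay on MDA-MB-231 cells (Homo sapiens) for inhibition, read by sulforhodamine B assay, with a stated time of 48 h; a lower number here means a stronger inhibitor of growth, a higher number a weaker inhibitor of growth:

compound 1 `COc1ccc2c(c1)NC(=O)CN2c1nc(NCCCO)nc2ccccc12` 10.2 nM
compound 2 `COc1ccc2c(c1)NC(=O)CN2c1nc(NCc2ccncc2)nc2ccccc12` 73.6 nM
compound 3 `CCOc1nc(N2CC(=O)Nc3cc(OC)ccc32)c2ccccc2n1` 15.4 nM

Compound 3 holds the second highest of the three numbers. Its step from compound 1 is small, a 1.5-fold higher number from compound 1 to compound 3 (0.18 log units; within the scatter), while the step from compound 2, a 4.8-fold lower number from compound 2 to compound 3 (0.68 log units; beyond the scatter), is modest and beyond the scatter. Going by the values given here, the only other step, a 7.2-fold higher number from compound 1 to compound 2 (0.86 log units; beyond the scatter), shows that the two amino substituents differ from each other by a modest margin.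

Compound 4 `COc1ccc2c(c1)NC(=O)CN2c1nc(NC2CCCC2)nc2ccccc12` is not yet measured. Its change from compound 3 is cyclopentylamino in place of ethoxy on an aromatic carbon. Both measured steps into compound 3 bear on it, since each sets ethoxy against an amino substituent: one lies within the scatter and one is modest. Among the compounds with values here, no measured compound carries cyclopentylamino, so the direction is open. A step of no more than the modest size seen so far is expected, a 1.3-fold higher number from compound 3 to compound 4 (0.11 log units; within the scatter), in this assay. Compound 4 is expected to give about 20 nM, within 7 nM to 60 nM.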

Compound 4, concentration for 50% growth inhibition: 17.6 nM
Compound 4: the middle estimate sits 1.1-fold (0.06 log units) above what was measured; the measured number falls inside the stated range.
By their numbers in this assay, from the lowest: compounds 1, 3 and 4 (each within the scatter of the next); then compound 2.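

In this assay, exchanging ethoxy for cyclopentylamino on the aromatic carbon between two ring nitrogen atoms gives no separation (a 1.1-fold higher number from compound 3 to compound 4 (0.06 log units; within the scatter)), even though the entering group adds a five-membered non-aromatic ring of carbon only and a hydrogen-bond donor. On the nitrogen itself, cyclopentyl and 3-hydroxypropyl likewise stay within the scatter (a 1.7-fold higher number from compound 1 to compound 4 (0.24 log units; within the scatter)), so three quite different groups at this position give numbers that cannot be told apart, and compound 2 goes against this with its (pyridin-4-yl)methyl group (a 4.2-fold lower number from compound 2 to compound 4 (0.62 log units; beyond the scatter)). No measurement at hand accounts for this pattern.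

Going by these compounds, whether a benzyl group on the nitrogen would stand apart as (pyridin-4-yl)methyl does remains open. Also open, on these data alone, is whether a carboxylic acid or a chain longer than 3-hydroxypropyl would stay with compound 1, compound 3 and compound 4.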